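The source may report more compounds than this note shows. Statements on the series, on what has been measured and on what is new or still open speak of the compounds shown alone.

Of the compounds shown here, three have numbers so far in a functional assay on HeLa cells (Homo sapiens) for antiproliferative activity, read by MTT assay, with a stated time of 72 h; a lower number here means a stronger inhibitor, a higher number a weaker inhibitor. Compound 1 (`O=C(NCc1ccccc1)c1csc(NC(=S)Nc2ccc(Cl)cc2)n1`) gives 76000 nM, compound 2 (`CC(=O)NNC(=O)c1csc2ncc(-c3ccc(C)cc3)n12`) gives 74200 nM, and compound 3 (`CCC(=O)NNC(=O)c1csc2ncc(-c3ccc(C)cc3)n12`) gives 13000 nM. Compound 3 therefore holds the lowest number of the three, and its distance from each of the other two lies beyond the scatter. Compound 4 (`CCCC(=O)NNC(=O)c1csc2ncc(-c3ccc(C)cc3)n12`) is still unmeasured. The change leading to it is methyl in place of hydrogen on a saturated chain carbon, two bonds along the chain from a carbonyl carbon, so that ethyl becomes propyl. Within the data shown here, only one measured step bears on this change. It is a 5.7-fold lower number from compound 2 to compound 3 (0.76 log units; beyond the scatter), a modest step beyond the scatter, made by methyl in place of hydrogen on a saturated chain carbon bound to a carbonyl carbon. A single step does not establish a trend, and the new methyl sits one bond further out along the chain. In this assay a further lowering in the same direction is therefore expected, but a smaller one that may not clear the scatter. The expected change is a 1.6-fold lower number from compound 3 to compound 4 (0.21 log units; within the scatter). Compound 4 is estimated at 8000 nM, with an expected range from 2500 nM to 30000 nM.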

Compound 4, half-maximal inhibitory concentration: 45600 nM
For compound 4 the middle estimate is 5.7-fold (0.76 log units) below the measured one; measured number above the stated range.
By their numbers in this assay, from the lowest: compound 3; then compounds 4, 2 and 1 (each within the scatter of the next).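

In this assay the same replacement of hydrogen by methyl now runs the other way along this chain: on a saturated chain carbon, two bonds along the chain from a carbonyl carbon, it gives a 3.5-fold higher number from compound 3 to compound 4 (0.55 log units; beyond the scatter) where, on the carbon bound to the carbonyl carbon, it had given a 5.7-fold lower number from compound 2 to compound 3 (0.76 log units; beyond the scatter) in the earlier pair. Lengthening the chain therefore does not keep lowering the number, and the step of a 1.6-fold lower number from compound 2 to compound 4 (0.21 log units; within the scatter) shows that ethyl in place of hydrogen on the carbon bound to the carbonyl carbon leaves no change beyond the scatter, so that among these three acyl compounds only compound 3, with its propanoyl group, stands apart from the other two. Nothing available explains why the direction turns between the ethyl and the propyl chain.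

The compounds shown leave open whether a branched chain such as isopropyl or a small ring such as cyclopropyl, with its carbons held closer to the carbonyl carbon, would stay with compound 3 or fall in with compound 4. They also leave open whether a longer chain such as butyl, or a hydroxyl or an amine placed on the propyl chain, would follow compound 4 in this assay.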